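Phenyl in place of fluoro on an inactive hydrazone set

The source may hold more compounds than are shown below. What is called first, only, known or untested is meant among the compounds shown, and "the series" means these compounds.

Compound 1 `CC1CC/C(=N\Nc2ccc(F)cc2)c2ncc(C(=O)O)c(=O)n21` was tested in a functional assay on the whole organism for inhibition, with Rattus norvegicus as the target (a lower number here means that less compound is needed, a higher number that more compound is needed for the effect), and compound 1 reaches only the limit of > 1000 umol/kg. Compound 2 `CC1CC/C(=N\Nc2ccccc2Cl)c2ncc(C(=O)O)c(=O)n21` likewise gives only a limit in this assay, namely > 1000 umol/kg. Compound 3 `CC1CC/C(=N\Nc2ccccc2I)c2ncc(C(=O)O)c(=O)n21` also stops at a limit, > 1000 umol/kg. The steps a step that the two limits leave unreadable from compound 1 to compound 2, a step that the two limits leave unreadable from compound 1 to compound 3 and a step that the two limits leave unreadable from compound 2 to compound 3 are thus not readable; this is the limit of > 1000 umol/kg in this assay, at which 3 of the 3 values shown sit. Compound 4 `CC1CC/C(=N\Nc2ccc(-c3ccccc3)cc2)c2ncc(C(=O)O)c(=O)n21` differs from compound 1 by phenyl in place of fluoro on an aromatic carbon. For the measured compounds named here, no measured step bears directly on this change, and none of the measured changes on the phenyl moved any compound off the limit. Compound 4 is therefore expected to stay near the limit, with an expected step that the limit leaves unreadable from compound 1 to compound 4. The estimate for compound 4 is 1500 umol/kg, between 400 umol/kg and 6000 umol/kg.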

Compound 4, dose for 50% inhibition: > 100 umol/kg
Compound 4: a limit, no number; the forecaster's own chance of this, stated with the estimate: 85%; the middle value is on the limit's open side.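

Compound 4, like compound 1, gives only a limit in this assay, so the step between these two compounds cannot be read. The compounds shown leave open what dose of any of them would produce the effect.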